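The source may hold more compounds than are shown below. What is called first, only, known or untested is meant among the compounds shown, and "the series" means these compounds.

Two compounds share a core in which a propyl or butyl chain links a phenoxy group to a piperidine carrying a bis(4-fluorophenyl)methyl substituent. Compound 1 `COc1cc(C(C)=O)ccc1OCCCCN1CCC(C(c2ccc(F)cc2)c2ccc(F)cc2)CC1` is the tighter binder of the two: in a functional assay (aorta) with Oryctolagus cuniculus as the target (on this read-out lower numbers stand for tighter binding and higher numbers for weaker binding), compound 1 gives 2.51 nM. Compound 2 `COc1cc(C(=O)O)ccc1OCCCN1CCC(C(c2ccc(F)cc2)c2ccc(F)cc2)CC1` carries a carboxylic acid on the aromatic ring at the end of the chain, and in this assay compound 2 gives 79.4 nM. Among the measured compounds shown here, compound 2 therefore stands at the highest number of the two measured, with compound 1 as its only neighbour, far enough apart that the gap lies beyond the usual scatter.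

Compound 3 `COc1ccc(OCCCN2CCC(C(c3ccc(F)cc3)c3ccc(F)cc3)CC2)cc1` has not yet been measured. It differs from compound 2 in one place: 4-methoxyphenyl in place of 4-carboxy-2-methoxyphenyl on an oxygen on a saturated carbon. For the measured compounds named here, no measured pair shows this exact change, so the size of the step can only be guessed from what the two measured compounds show. Since the neutral compound 1 sits far below the acid-bearing compound 2, a move to a lower number is expected for compound 3, of a size beyond the scatter, a 7.9-fold lower number from compound 2 to compound 3 (0.90 log units; beyond the scatter). In this assay compound 3 is estimated at 10 nM, with a likely range from 3 nM to 40 nM.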

Compound 3, dissociation constant: 2.51 nM
The estimate for compound 3 lay 4.0-fold (0.60 log units) above the measured number, and the stated range ends above it.
By their numbers in this assay, from the lowest: compounds 1 and 3 (each within the scatter of the next); then compound 2.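

On an oxygen on a saturated carbon, putting 4-methoxyphenyl in place of 4-carboxy-2-methoxyphenyl gives a 32-fold lower number from compound 2 to compound 3 (1.50 log units; beyond the scatter) in this assay and counts as a large change. Among the compounds shown here, this is the first pair here that differs in one place only, so a large shift in the number can now be tied to this one group, whereas the earlier gap came with differences in both the chain and the ring. The swap is still not a single small edit, since the carboxy group leaves and the methoxy group's printed position changes from 2 to 4, and nothing measured here gives a reason for the size of the step.

For the compounds shown here, it remains open how much of the step goes with the loss of the carboxylic acid and how much with the position of the methoxy group, which a ring carrying only one of these changes could separate. Also open, going by these compounds, is where an amide or a nitrile in place of the carboxylic acid would fall, and whether a butyl chain would alter the size of this step.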